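Phenyl for Methyl on the Ring Carbon of Compound 2

The source may hold more compounds than are shown below. What is called first, only, known or untested is meant among the compounds shown, and "the series" means these compounds.

Compound 1 `N#C/N=C1\N(CCCCCOc2ccc(Cl)cc2)C(=O)CN1c1ccncc1`: in a functional assay on MCF7 cells (Homo sapiens) for cytotoxicity (a lower number here means a stronger inhibitor, a higher number a weaker inhibitor), compound 1 gives 5360 nM.
Compound 2 `CC1C(=O)N(CCCCCOc2ccc(Cl)cc2)/C(=N\C#N)N1c1ccncc1`: in this assay compound 2 gives 9260 nM.
Compound 3 `CC1C(=O)N(CCCCCCCOc2ccc(Cl)cc2)/C(=N\C#N)N1c1ccncc1`: in this assay compound 3 gives 460 nM.

Compound 2 stands at the highest of the three numbers. Its nearest neighbour is compound 1, with a 1.7-fold higher number from compound 1 to compound 2 (0.24 log units; within the scatter), while a 20-fold lower number from compound 2 to compound 3 (1.30 log units; beyond the scatter). Compound 4 `N#C/N=C1\N(CCCCCOc2ccc(Cl)cc2)C(=O)C(c2ccccc2)N1c1ccncc1` differs from compound 2 by phenyl in place of methyl on a saturated ring carbon. Within the data shown here, of the measured steps only the one from compound 1 to compound 2 touches this ring carbon, and that step stayed within the scatter; the step from compound 2 to compound 3 concerns the chain and does not bear on this change. On this basis only a small step is expected, a 1.3-fold lower number from compound 2 to compound 4 (0.12 log units; within the scatter), with the direction uncertain. The estimate for compound 4 in this assay is 7000 nM, within a range of 1500 nM to 25000 nM.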

Compound 4, half-maximal inhibitory concentration: 1000 nM
Estimate against measurement, compound 4: 7.0-fold (0.85 log units) above; the whole stated range lies above it.
By their numbers in this assay, from the lowest: compound 3; then compound 4; then compounds 1 and 2 (each within the scatter of the next).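

In this assay, this saturated ring carbon proves able to move the number beyond the scatter: phenyl in place of methyl gives a 9.3-fold lower number from compound 2 to compound 4 (0.97 log units; beyond the scatter), and phenyl in place of hydrogen gives a 5.4-fold lower number from compound 1 to compound 4 (0.73 log units; beyond the scatter). The earlier change here, methyl in place of hydrogen, gave only a 1.7-fold higher number from compound 1 to compound 2 (0.24 log units; within the scatter), so the size of the group entering matters at this position. Nothing measured here bears on what lies behind this result.

On these data alone, whether a benzyl or pyridin-4-yl group on this carbon would do the same remains open. So does whether phenyl here would combine with the longer chain of compound 3.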